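Chloro scan on two related phenyl keto-acid cores

The source may hold more compounds than are shown below. What is called first, only, known or untested is meant among the compounds shown, and "the series" means these compounds.

Compound 1 `O=C(O)C(=O)/C=C(\O)c1ccccc1` gives 0% in an assay for inhibition of kynurenine 3-monooxygenase (Rattus norvegicus), tested at 10 uM; on this read-out lower numbers stand for less inhibition and higher numbers for more inhibition at the one concentration tested (going by the name of the read-out). Compound 2 `O=C(O)C(=O)/C=C(\O)c1ccccc1Cl` carries one extra substituent and gives 33% in this assay; the change chloro in place of hydrogen on an aromatic carbon produced a number 33 percentage points higher from compound 1 to compound 2 (beyond the scatter). Compound 3 `N/C(=C\C(=O)c1ccccc1Cl)C(=O)O` rests on a different core, and the difference between the two cores is not broken down here; in this assay compound 3 gives 19%, which stands between the numbers of compound 1 and compound 2.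

Compound 4 `N/C(=C\C(=O)c1cccc(Cl)c1Cl)C(=O)O` is not yet measured. It derives from compound 3 by chloro in place of hydrogen on an aromatic carbon. Within the data shown here, this is the same kind of change as the one from compound 1 to compound 2, but not the same: there the chloro entered ortho to a group of 8 heavy atoms, whereas here it enters ortho to a chloro group and meta to a group of 8 heavy atoms, on the other core.

Among the measured compounds shown here, with only one earlier step of this kind, and that one at a different place, the expectation for compound 4 is a gain smaller than the earlier step, a number 16 percentage points higher from compound 3 to compound 4 (beyond the scatter), resting on compound 3 at 19% and the step of a number 33 percentage points higher from compound 1 to compound 2 (beyond the scatter). In this assay compound 4 is estimated at 35%, with a likely range from 12% to 60%.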

Compound 4, a percentage reported as inhibition, at one concentration (the size of the read-out at that concentration, not a potency): 32%
Compound 4: the middle estimate sits 3 percentage points above what was measured, within the range that was stated.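

In this assay, chloro in place of hydrogen on an aromatic carbon again gives a gain on the second core, a number 13 percentage points higher from compound 3 to compound 4 (beyond the scatter). The direction of the step carries over from one core to the other, but its size does not: the same change on two cores in this assay, a number 33 percentage points higher (beyond the scatter) from compound 1 to compound 2 and a number 13 percentage points higher (beyond the scatter) from compound 3 to compound 4, 20 percentage points apart, beyond the scatter of two such steps. These two steps do not show whether the smaller gain belongs to the core or to the place of the chloro: in compound 4 it enters ortho to a chloro group and meta to a group of 8 heavy atoms, so core and place change together, and two steps give no rule for the series.

Still open, on these data alone, is whether a chloro at the same place on both cores would give steps of equal size, which would separate the two factors. Also open, as far as these compounds go, is how other ring substituents, such as methoxy or nitrile, or an ester or amide in place of the carboxylic acid, would behave on either core.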